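Replacing 1H-pyrazol-5-yl with furan-2-yl on the shared core

This account rests on a few compounds, and the source may have more. Where it says the series, first, only, none or still open, it means among the compounds named here.

Measured in a functional assay on A-375 cells (Homo sapiens) for antiproliferative activity; on this read-out lower numbers stand for stronger inhibition and higher numbers for weaker inhibition:
Compound 1 `O=C(Nc1ccc(-c2nccs2)cc1)C1CCCN(Cc2ccc(F)c(F)c2)C1`: 240 nM
Compound 2 `O=C(Nc1ccc(-c2ccn[nH]2)cc1)C1CCCN(Cc2ccc(F)c(F)c2)C1`: 520 nM

Among the compounds with values here, compound 2, at 520 nM, carries the higher of the two numbers measured so far in this assay. Compound 3 `O=C(Nc1ccc(-c2ccco2)cc1)C1CCCN(Cc2ccc(F)c(F)c2)C1` departs from it in one place, (furan-2-yl in place of 1H-pyrazol-5-yl on an aromatic carbon), with furan-2-yl in place of 1H-pyrazol-5-yl on an aromatic carbon, para to a large group.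

Within the data shown here, only one measured step bears on this change: a 2.2-fold higher number from compound 1 to compound 2 (0.34 log units; beyond the scatter). It is modest, and it replaced 1,3-thiazol-2-yl with 1H-pyrazol-5-yl at the same place. Among the measured compounds shown here, no furan-2-yl compound has been measured, so this step is only an indirect guide. For the measured compounds named here, the sole other group measured there, in compound 1, gave 240 nM, so a shift toward a lower number seems more likely than one toward a higher number. The expected change is a 1.6-fold lower number from compound 2 to compound 3 (0.21 log units; within the scatter), a small step that may not clear the scatter. For compound 3 the estimate is 320 nM, with an expected range from 130 nM to 750 nM.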

Compound 3, half-maximal inhibitory concentration: 1040 nM
The estimate for compound 3 lay 3.3-fold (0.51 log units) below the measured number; the whole stated range lies below it.
By their numbers in this assay, from the lowest: compound 1; then compounds 2 and 3 (each within the scatter of the next).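

In this assay, exchanging 1H-pyrazol-5-yl for furan-2-yl removes the hydrogen-bond donor counted on the leaving group, yet the result is a 2.0-fold higher number from compound 2 to compound 3 (0.30 log units; within the scatter), so this exchange does not separate the two compounds on this read-out. The comparison with the thiazole compound is clearer, with furan-2-yl in place of 1,3-thiazol-2-yl giving a 4.3-fold higher number from compound 1 to compound 3 (0.64 log units; beyond the scatter), which leaves compound 1 as the strongest of the three and shows that this position does respond to a change between five-membered aromatic rings. Nothing available explains why 1,3-thiazol-2-yl stands apart from the other two groups.

The three compounds leave open whether the advantage of compound 1 is particular to 1,3-thiazol-2-yl or would be shared by other five-membered aromatic rings carrying two hetero atoms. They also leave open how the number would respond to a quite different group on this aromatic carbon, such as an amine or a carboxylic acid, since every group shown there is a five-membered aromatic ring.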